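Methoxy Added to the Anilino Ring of a Thiophene Acid

This account rests on a few compounds, and the source may have more. Where it says the series, first, only, none or still open, it means among the compounds named here.

Compound 1, `COC(=O)c1c(Nc2ccccc2)sc(C(=O)c2ccc(OC)cc2)c1C`, gives 48.1% in a functional assay, with a stated time of 150 min, tested at 30 ug/mL; a lower number here means a weaker effect, a higher number a stronger effect of the compound at the concentration tested.
Compound 2, `COc1ccc(C(=O)c2sc(Nc3ccccc3)c(C(=O)O)c2C)cc1`, gives 59.5% in this assay.

Among the compounds with values here, compound 2 stands highest of the two numbers measured so far in this assay, and its nearest neighbour is compound 1. Within the data shown here, the single measured step, a number 11.4 percentage points higher from compound 1 to compound 2 (beyond the scatter), came from a change at the ester: hydrogen in place of methyl on an oxygen next to a carbonyl group.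

Compound 3, `COc1ccc(Nc2sc(C(=O)c3ccc(OC)cc3)c(C)c2C(=O)O)cc1`, keeps the free acid of compound 2 and differs from it by methoxy in place of hydrogen on an aromatic carbon. Among the measured compounds shown here, the one measured step concerns the ester and not the anilino ring, so no measured step bears directly on this change. With nothing to point either way, the expectation for this assay is a step of no size beyond the scatter, in either direction. Compound 3 is therefore expected to give about 58%, with a likely range from 38% to 76%. For the measured compounds named here, the expected step from compound 2 is a number 1.5 percentage points lower from compound 2 to compound 3 (within the scatter), and it is wide; only one step is known, and that step is unrelated to the anilino ring.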

Compound 3, a percentage reported as activity, at one concentration (the size of the read-out at that concentration, not a potency): 41.2%
Compound 3: middle estimate off by 16.8 percentage points, on the high side; low and high end bracket the measured number.
By their numbers in this assay, from the lowest: compounds 3 and 1 (each within the scatter of the next); then compound 2.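

Replacing hydrogen with methoxy on the anilino ring, para to a large group, turns phenyl into 4-methoxyphenyl and gives a number 18.3 percentage points lower from compound 2 to compound 3 (beyond the scatter) in this assay. Within the data shown here, the earlier step concerned only the ester, so this is the first sign that the anilino ring is also a place where a change can move the read-out, and that an addition of only 2 heavy atoms is enough to do so. No measurement shown here accounts for the drop, so the result records what happened without explaining it.

The compounds shown leave open whether the drop belongs to methoxy itself, or whether a hydroxyl group, a fluorine atom or a longer chain such as ethoxy in the same place would lower the read-out as well. They also leave open whether methoxy on another carbon of this ring would act in the same way, and whether the step would be repeated if the free acid were replaced by the methyl ester of compound 1.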